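A few compounds are considered here, and "the series" means these few. Any claim that something is new, unique, unknown or untested is made for them only; others in the source may bear on it.

Compound 1 `Cc1cc(S(N)(=O)=O)ccc1NC(=O)COc1ccc2ccccc2c1C(=O)c1ccccc1` gives 33800 nM in an ADME assay on C8166 cells (Homo sapiens) for cytotoxicity, read by colorimetric assay and MTT assay; on this read-out lower numbers stand for higher toxicity in this test and higher numbers for lower toxicity in this test. Compound 2 `Cc1ccc(C)c(C(=O)c2c(OCC(=O)Nc3ccc(S(N)(=O)=O)cc3C)ccc3ccccc23)c1` gives 47500 nM. Compound 3 `Cc1cc(S(N)(=O)=O)ccc1NC(=O)COc1ccc2cc(Br)ccc2c1C(=O)c1ccccc1` gives 29200 nM.

Compound 3 has the lowest of the three numbers, but its gaps to compound 1 and to compound 2 are both within the scatter, so the three compounds sit together. Compound 4 `Cc1cc(C)cc(C(=O)c2c(OCC(=O)Nc3ccc(S(N)(=O)=O)cc3C)ccc3cc(Br)ccc23)c1` differs from compound 3 by 3,5-dimethylphenyl in place of phenyl on a carbonyl carbon. Among the compounds with values here, one measured step bears on this: a 1.4-fold higher number from compound 1 to compound 2 (0.15 log units; within the scatter), which also replaced phenyl on the carbonyl carbon with a dimethylphenyl, though a 2,5-dimethylphenyl rather than a 3,5-dimethylphenyl, and it stayed within the scatter. Compound 4 is therefore expected to show no step beyond the scatter in this assay, about a 1.2-fold higher number from compound 3 to compound 4 (0.09 log units; within the scatter). The estimate for compound 4 is 36000 nM, with a range from 17000 nM to 75000 nM.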

Compound 4, half-maximal cytotoxic concentration: 24500 nM
Compound 4: middle estimate off by 1.5-fold (0.17 log units), on the high side; the range from low to high includes it.
By their numbers in this assay, from the lowest: compounds 4, 3, 1 and 2 (each within the scatter of the next).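

Placing 3,5-dimethylphenyl in place of phenyl on the carbonyl carbon gives a 1.2-fold lower number from compound 3 to compound 4 (0.08 log units; within the scatter) in this assay. A second dimethylphenyl pattern, now on the core carrying bromo, therefore also stays within the scatter, as 2,5-dimethylphenyl did on the core of compound 1. No measurement shown explains this result. Still open, as far as these compounds go, is whether a group containing atoms other than carbon, such as an amine or a carboxylic acid on this phenyl ring, would move the number beyond the scatter.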